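The source may hold more compounds than are shown below. What is called first, only, known or untested is meant among the compounds shown, and "the series" means these compounds.

In a functional assay on MC-38 cells (Mus musculus) for antiproliferative activity (on this read-out higher numbers stand for weaker inhibition and lower numbers for stronger inhibition), compound 1 `O=S(=O)(Nc1cccc2cc[nH]c12)c1ccc(Cl)cc1` gives 7 ug/mL, while compound 2 `N#Cc1ccc(S(=O)(=O)Nc2cccc3cc[nH]c23)cc1` gives 1.8 ug/mL. The change chloro in place of cyano on an aromatic carbon made a step of a 3.9-fold higher number from compound 2 to compound 1 (0.59 log units; beyond the scatter). Compound 3 `COc1ccc(S(=O)(=O)Nc2cccc3c(C#N)c[nH]c23)cc1` gives 0.17 ug/mL, the lowest number of the three; the difference between its core and that of compound 2 is not broken down here. Compound 4 `COc1ccc(S(=O)(=O)Nc2cccc3c(Cl)c[nH]c23)cc1` has not yet been measured in this assay. It differs from compound 3 by chloro in place of cyano on an aromatic carbon, the same kind of change as that between compound 2 and compound 1, but here on a five-membered aromatic ring with one nitrogen in a fused system of two rings, rather than on a six-membered aromatic ring of carbon only, para to a large group. The earlier change gave a 3.9-fold higher number from compound 2 to compound 1 (0.59 log units; beyond the scatter), and a step of similar size is taken as the guide. Compound 4 is therefore expected to show a step of a 2.9-fold higher number from compound 3 to compound 4 (0.47 log units; beyond the scatter). Compound 4 is estimated at 0.5 ug/mL, likely between 0.17 ug/mL and 1.5 ug/mL.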

Compound 4, half-maximal inhibitory concentration: 0.2 ug/mL
Compound 4: the middle estimate sits 2.5-fold (0.40 log units) above what was measured; low and high end bracket the measured number.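

In this assay, among these compounds, chloro in place of cyano on the five-membered aromatic ring gave a 1.2-fold higher number from compound 3 to compound 4 (0.07 log units; within the scatter), so on this core the change has no step that can be told from the scatter. The size of the step therefore did not carry over from one core to the other: the same change on two cores in this assay, a 3.9-fold higher number (0.59 log units; beyond the scatter) from compound 2 to compound 1 and a 1.2-fold higher number (0.07 log units; within the scatter) from compound 3 to compound 4, 3.3-fold (0.52 log units) apart, beyond the scatter of two such steps This does not show what causes the gap, as the two pairs differ both in where the change sits and in the rest of the molecule, and two pairs set no rule for the series.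

The compounds shown leave open whether an amine or a carboxylic acid at this place on the five-membered ring would keep the number close to those of compound 3 and compound 4.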